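The compounds below may be only part of what the source reports. "The series", "measured", "known", "first", "only" and "open" are said of these compounds alone.

Measured compounds in an assay on membranes from HeLa cells for displacement of a labelled ligand from adenosine receptor A3 (Homo sapiens), read by scintillation counting, with a stated time of 180 min, tested at 1 uM; on this read-out higher numbers stand for more inhibition at the one concentration tested (going by the name of the read-out) and lower numbers for less inhibition:

- compound 1 `CC1=C(C(=O)CC(C)C)C(c2ccsc2)NC(=O)N1`: 14%
- compound 2 `CC1=C(C(=O)NC(C)C)C(c2ccsc2)NC(=O)N1`: 1%
- compound 3 `CC1=C(C(=O)OC2CCCC2)C(c2ccco2)NC(=O)N1`: 14%

Compound 3 stands level with compound 1 at the digits printed, and together they give the highest of the three numbers; compound 2 lies furthest from compound 3, its value being lower beyond the scatter. For the measured compounds named here, the only single-change step measured, a number 13 percentage points lower from compound 1 to compound 2 (beyond the scatter), is a modest fall on exchanging isopropylamino for isobutyl on a carbonyl carbon, and it does not touch the ring at the saturated ring carbon.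

Compound 4 `CC1=C(C(=O)OC2CCCC2)C(c2ccsc2)NC(=O)N1` is not yet measured. Relative to compound 3 it carries thiophen-3-yl in place of furan-2-yl on a saturated ring carbon. Going by the values given here, no measured step bears on this exchange directly. Among the compounds with values here, compound 1 and compound 2 already carry thiophen-3-yl, while compound 3 carries furan-2-yl, yet compound 1 and compound 3 differ also on the carbonyl carbon, so their pair shows only that the two values coincide. On this basis the step expected is no change at the digits printed from compound 3 to compound 4 (within the scatter), that is no change beyond the scatter. Compound 4 is therefore estimated at 14%, within 4% to 24%.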

Compound 4, a percentage reported as inhibition, at one concentration (the size of the read-out at that concentration, not a potency): 5%
The estimate for compound 4 lay 9 percentage points above the measured number; measured number inside the range.
By their numbers in this assay, from the lowest: compounds 2, 4, 1 and 3 (each within the scatter of the next, the first and the last beyond it).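

In this assay, for the compounds shown here, thiophen-3-yl in place of furan-2-yl on a saturated ring carbon, with the cyclopentyloxy on the carbonyl carbon held constant, gives a number 9 percentage points lower from compound 3 to compound 4 (within the scatter) and so gives the first direct reading of this exchange, which does not separate the two rings. With thiophen-3-yl held constant, cyclopentyloxy in place of isopropylamino gives a number 4 percentage points higher from compound 2 to compound 4 (within the scatter) and cyclopentyloxy in place of isobutyl gives a number 9 percentage points lower from compound 1 to compound 4 (within the scatter) and thus neither exchange on the carbonyl carbon separates from the scatter, although the step between the other two groups does. Nothing available bears on the cause of these steps.

Still open, on these data alone, is whether a phenyl, a thiophen-2-yl or a furan-3-yl on the saturated ring carbon would read any differently. Also open, as far as these compounds go, is whether furan-2-yl would behave the same alongside isobutyl or isopropylamino on the carbonyl carbon.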